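The compounds below may be only part of what the source reports. "The series", "measured", "known", "first", "only" and "open" are said of these compounds alone.

Going by the values given here, in a functional assay for inhibition, with Homo sapiens as the target (on this read-out higher numbers stand for weaker inhibition and lower numbers for stronger inhibition), compound 1 (`O=C(NC[C@H](NS(=O)(=O)c1ccccc1)C(=O)O)c1cc2cc(OCC3CCNCC3)ccc2[nH]1`) gives 13 nM and so holds the lower of the two numbers known so far. Compound 2 (`O=C(NC[C@H](NS(=O)(=O)c1ccccc1)C(=O)O)c1cc2cc(OCC3CCNCC3)ccc2n1Cc1ccccc1`) gives 150 nM in the same read-out. Among the compounds with values here, the only measured step is a 12-fold higher number from compound 1 to compound 2 (1.06 log units; beyond the scatter) and it comes with benzyl in place of hydrogen on an aromatic nitrogen.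

Compound 3 (`O=C(NC[C@H](NS(=O)(=O)c1ccccc1)C(=O)O)c1cc2cc(OCCn3ccnc3)ccc2[nH]1`) differs from compound 1 at another place, with (1H-imidazol-1-yl)methyl in place of piperidin-4-yl on a saturated chain carbon bound to an oxygen on an aromatic ring. Within the data shown here, the measured step therefore bears on this change only indirectly, and no measured compound alters this side chain. Among the measured compounds shown here, with compound 2 at 150 nM as the only guide to how far one change can move the number, a large step towards a higher number is expected, though with wide uncertainty. The estimated step is a 62-fold higher number from compound 1 to compound 3 (1.79 log units; beyond the scatter) on this reasoning. Compound 3 is expected at 800 nM within an estimated range of 100 nM to 8000 nM for now.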

Compound 3, half-maximal inhibitory concentration: 45 nM
Beside the measured number, compound 3's estimate is 18-fold (1.25 log units) above it; the measured number lies below the stated range.
By their numbers in this assay, from the lowest: compound 1; then compound 3; then compound 2.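

In this assay, going by these compounds alone, the result gives the first reading on the side chain on the oxygen: (1H-imidazol-1-yl)methyl in place of piperidin-4-yl on a saturated chain carbon bound to an oxygen on an aromatic ring gives a 3.5-fold higher number from compound 1 to compound 3 (0.54 log units; beyond the scatter). This step is modest and beyond the scatter, whereas the step on the aromatic nitrogen, a 12-fold higher number from compound 1 to compound 2 (1.06 log units; beyond the scatter), is large, so here a five-membered aromatic ring with 0 hydrogen-bond donors replaces a six-membered non-aromatic ring with 1 hydrogen-bond donor at a modest cost in this read-out. No evidence at hand accounts for the size of this step.

The change from (piperidin-4-yl)methoxy to 2-(1H-imidazol-1-yl)ethoxy alters the ring and its place on the chain at once, and the compounds shown do not separate the two, which a 2-(piperidin-4-yl)ethoxy side chain or an open-chain amine such as 2-aminoethoxy could begin to do. As far as these compounds go, it also remains open whether benzyl on the aromatic nitrogen would move the number by the same amount on a core that carries the imidazole side chain.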